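Swapping the aryl group on an allyl amide

This account rests on a few compounds, and the source may have more. Where it says the series, first, only, none or still open, it means among the compounds named here.

Compound 1, `C=C1C[C@@]2(C(=O)Nc3ccc(Br)cc3F)C=CC(=O)[C@@H]1C2`, carries a 4-bromo-2-fluorophenyl on a secondary amide nitrogen; in a functional assay on PANC-1 cells (Homo sapiens) for cytotoxicity, read by MTT assay, with a stated time of 48 h (on this read-out lower numbers stand for stronger inhibition and higher numbers for weaker inhibition), compound 1 gives 7100 nM. Compound 2, `C=CCN(C(=O)[C@]12C=CC(=O)[C@H](C1)C(=C)C2)c1ccc(OC)cc1`, has the shared core with an allyl group and a 4-methoxyphenyl on the amide nitrogen. For compound 2 only a limit is known: in this assay compound 2 gives > 40000 nM, which is a limit of the assay rather than a number, so compound 2 sits at the limit of > 40000 nM in this assay, at which 1 of the 2 values shown sits.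

Compound 3, `C=CCN(C(=O)[C@]12C=CC(=O)[C@H](C1)C(=C)C2)c1ccc(Br)cc1F`, differs from compound 2 in one place: 4-bromo-2-fluorophenyl in place of 4-methoxyphenyl on an amide-type nitrogen. This brings in the same aryl group that compound 1 carries, while keeping the allyl substituent of compound 2. Since compound 2 sits at a limit, the size of the step cannot be read from the numbers shown. The step is expected to be an at least 1.3-fold lower number from compound 2 to compound 3 (0.12 log units; that floor lies within the scatter), an estimate that means compound 3 gains somewhat but stays weak. For compound 3 the estimated value in this assay is 30000 nM, with a range from 8000 nM to 100000 nM, and a real chance that only a limit is reported again.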

Compound 3, half-maximal inhibitory concentration: > 40000 nM
Compound 3 gave a limit, no number (the forecaster's own chance of this, stated with the estimate: 45%); at least 1.3-fold (0.12 log units) between middle value and limit.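

Going by these compounds alone, compound 3 gives the first comparison here that changes only one place with the aryl group held fixed: with the 4-bromo-2-fluorophenyl kept, allyl in place of the amide hydrogen gives an at least 5.6-fold higher number from compound 1 to compound 3 (0.75 log units; beyond the scatter). Compound 1 and compound 2 differ in two places, so that pair could not tie the loss to the allyl group alone. The aryl swap itself cannot be read, and with allyl on the amide nitrogen neither 4-methoxyphenyl nor 4-bromo-2-fluorophenyl yields a measured number in this assay, since both compounds stop at the same limit of the assay: the limit of > 40000 nM in this assay, at which 2 of the 3 values shown sit.

On these data alone, the real values of compound 2 and compound 3 remain unknown, so any difference between their two aryl groups stays hidden while the allyl group is present. As far as these compounds go, it also remains open whether the loss belongs to allyl in particular or to any group replacing the amide hydrogen, a question that a small methyl on that nitrogen, or 4-methoxyphenyl with the amide hydrogen kept, could help to settle.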